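Trimethoxyphenyl Swap on the Imidazolone Arm of a Chalcone

A few compounds are considered here, and "the series" means these few. Any claim that something is new, unique, unknown or untested is made for them only; others in the source may bear on it.

Of the compounds shown here, two have been measured in a functional assay on HCT-116 cells (Homo sapiens) for inhibition; on this read-out lower numbers stand for stronger inhibition of growth and higher numbers for weaker inhibition of growth. Compound 1, `COc1cc(/C=C/C(=O)c2cccc(-n3cc(-c4ccccc4)[nH]c3=O)c2)ccc1O`, carries a methoxy and a hydroxy group on its chalcone ring; in this assay compound 1 gives 1400 nM. Compound 2, `COc1cc(/C=C/C(=O)c2cccc(-n3cc(-c4ccccc4)[nH]c3=O)c2)cc(OC)c1OC`, carries three methoxy groups there instead; in this assay compound 2 gives 330 nM, the lower of the two numbers, and the gap to compound 1 lies beyond the usual scatter.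

Compound 3, `COc1cc(/C=C/C(=O)c2cccc(-n3cc(-c4cc(OC)c(OC)c(OC)c4)[nH]c3=O)c2)cc(OC)c1OC`, keeps the whole of compound 2 and changes only the phenyl on the five-membered ring: 3,4,5-trimethoxyphenyl in place of phenyl on an aromatic carbon. Going by the values given here, no measured pair in this set differs in just that place, so the step cannot be read off another example. The expectation for the step from compound 2 to compound 3 in this assay is a modest move toward stronger inhibition, a 1.7-fold lower number from compound 2 to compound 3 (0.22 log units; within the scatter), of a size that may not exceed the scatter. On that basis compound 3 is estimated at 200 nM, with a plausible range from 60 nM to 700 nM.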

Compound 3, concentration for 50% growth inhibition: 740 nM
Beside the measured number, compound 3's estimate is 3.7-fold (0.57 log units) below it, outside the stated range (above it).
By their numbers in this assay, from the lowest: compound 2; then compounds 3 and 1 (each within the scatter of the next).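

In this assay, the position on the five-membered ring does respond to what it carries: 3,4,5-trimethoxyphenyl in place of phenyl gives a 2.2-fold higher number from compound 2 to compound 3 (0.35 log units; beyond the scatter), a modest weakening of growth inhibition that lies beyond the usual scatter. The step enlarges this substituent and adds three hydrogen-bond acceptors, yet inhibition does not vanish, since compound 3 still gives 740 nM in this assay, so a much larger aromatic group can sit on this carbon at a modest cost. Nothing available explains why this change weakens inhibition, so the step stands as an observation without a cause.

With a single step at this position, the compounds shown leave open whether the weakening needs all three methoxy groups or would already appear with one methoxy on the phenyl. They also leave open how a small group such as a fluorine, or an amine, on that phenyl would compare with the unsubstituted phenyl of compound 2.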